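Methoxy added to the aryl arm of compound 2

A few compounds are considered here, and "the series" means these few. Any claim that something is new, unique, unknown or untested is made for them only; others in the source may bear on it.

Measured compounds:
compound 1, `Nc1cc(N)c2nc(-c3ccccc3)c(NCc3ccc(Cl)c(Cl)c3)nc2c1`: 17000 nM
compound 2, `COc1ccc(CNc2nc3cc(N)cc(N)c3nc2-c2ccccc2)cc1OC`: 7940 nM
compound 3, `CCOC(=O)[C@H](CCC(=O)O)NC(=O)c1ccc(Sc2nc3cc(N)cc(N)c3nc2-c2ccccc2)cc1`: 28200 nM

In a functional assay on COLO 205 cells (Homo sapiens) for inhibition, read by sulforhodamine B assay, with a stated time of 48 h (a higher number here means a weaker inhibitor of growth, a lower number a stronger inhibitor of growth), compound 2 gives 7940 nM, the lowest of the three numbers, with compound 1 nearest and compound 3 furthest, both beyond the scatter. For the measured compounds named here, the only single-point step measured is a 2.1-fold lower number from compound 1 to compound 2 (0.33 log units; beyond the scatter), a modest change on exchanging the substituents of that ring. Compound 4 `COc1cc(CNc2nc3cc(N)cc(N)c3nc2-c2ccccc2)cc(OC)c1OC` differs from compound 2 by methoxy in place of hydrogen on an aromatic carbon. Going by the values given here, no measured step adds a group to an already substituted ring of this kind, so that step bears on the change only loosely, suggesting small effects from such substituents. The expected step is therefore a 1.1-fold lower number from compound 2 to compound 4 (0.05 log units; within the scatter), not beyond the scatter. Compound 4 is estimated at 7000 nM, ranging from 3000 nM to 17000 nM.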

Compound 4, concentration for 50% growth inhibition: 3800 nM
The estimate for compound 4 lay 1.8-fold (0.27 log units) above the measured number; low and high end bracket the measured number.
By their numbers in this assay, from the lowest: compound 4; then compound 2; then compounds 1 and 3 (each within the scatter of the next).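

In this assay, adding one methoxy to an aryl ring that already carries methoxy groups gives a 2.1-fold lower number from compound 2 to compound 4 (0.32 log units; beyond the scatter), so a single added group at this position moves the number beyond the scatter. For the compounds shown here, earlier, the only step at this arm, a 2.1-fold lower number from compound 1 to compound 2 (0.33 log units; beyond the scatter), exchanged the ring substituents and did not test an added group. No measurement here gives a cause for the new step. Open, going by these compounds, is whether a hydroxyl group or an ethoxy group on this aromatic carbon would lower the number further than methoxy does. Also open, on these data alone, is whether methoxy here alone, with the other two methoxy groups replaced by chlorine, gives a similar step.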